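Cyclopentyl in place of methyl on the shared core

A few compounds are considered here, and "the series" means these few. Any claim that something is new, unique, unknown or untested is made for them only; others in the source may bear on it.

In an ADME assay on microsomes from liver (Rattus norvegicus) for metabolic stability, with a stated time of 60 min, tested at 1 uM (a lower number here means that less of the compound is left, a higher number that more of the compound is left), compound 3 `COc1cc(-c2cnn3cc(OC)c(C)nc23)ccn1` stands lowest of the three measured compounds at 13%. Compound 1 `COc1cc(-c2cnn3cc(OC)c(-c4cnn(C)c4)nc23)ccn1` gives 56% and compound 2 `COc1cc(-c2cnn3cc(OC)c(-c4cc(C)no4)nc23)ccn1` gives 62%. Exchanging the 1-methyl-1H-pyrazol-4-yl for the 3-methyl-1,2-oxazol-5-yl gives a number 6 percentage points higher from compound 1 to compound 2 (within the scatter).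

Compound 4 `COc1cc(-c2cnn3cc(OC)c(C4CCCC4)nc23)ccn1` differs from compound 3 at the same aromatic carbon: cyclopentyl in place of methyl on an aromatic carbon. Among the measured compounds shown here, two measured steps bear on this place, a number 43 percentage points lower from compound 1 to compound 3 (beyond the scatter) and a number 49 percentage points lower from compound 2 to compound 3 (beyond the scatter). Both are large, and both put methyl in place of a larger group, so a larger group here may leave more of the compound. For the measured compounds named here, neither step shows what a non-aromatic ring of carbon only does, and no measured compound carries one at this place. Only part of that gap is therefore expected to return, and the expected step is a number 9 percentage points higher from compound 3 to compound 4 (within the scatter). Compound 4 is estimated at 22%, with an expected range of 6% to 48%.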

Compound 4, percent of the compound remaining: 7%
For compound 4 the middle estimate is 15 percentage points above the measured one; the range from low to high includes it.
By their numbers in this assay, from the lowest: compounds 4 and 3 (each within the scatter of the next); then compounds 1 and 2 (each within the scatter of the next).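

In this assay, a larger group at this aromatic carbon is not enough on its own to give a high number: cyclopentyl and methyl cannot be told apart here, with a number 6 percentage points lower from compound 3 to compound 4 (within the scatter). The steps from the two compounds with heteroaromatic groups remain large, with a number 49 percentage points lower from compound 1 to compound 4 (beyond the scatter) and a number 55 percentage points lower from compound 2 to compound 4 (beyond the scatter), so among these four compounds the high numbers go with 1-methyl-1H-pyrazol-4-yl and 3-methyl-1,2-oxazol-5-yl, not with the heavy-atom count of the group. No available measurement accounts for this difference.

From the compounds shown here alone, it remains open whether a phenyl ring or a morpholine ring at this carbon would give numbers nearer to those of compound 1 and compound 2 or to those of compound 3 and compound 4. Which part of these compounds is lost during the incubation also remains open.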